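The source may report more compounds than this note shows. Statements on the series, on what has been measured and on what is new or still open speak of the compounds shown alone.

Working notes on the series in an ADME assay on microsomes from liver (Homo sapiens) for metabolic stability, read by LC-MS, tested at 1 uM; on this read-out higher numbers stand for fast clearance and lower numbers for slow clearance.

Compound 1 `c1cc([C@H]2CC[C@]3(CC2)OOC2(O3)C3CC4CC(C3)CC2C4)ccc1OCCOC1CCNCC1` opens the set. In this assay compound 1 gives < 7 mL.min-1.g-1, which is a limit of the assay rather than a number. Compound 2 `CC(C)(N)CCOc1ccc([C@H]2CC[C@]3(CC2)OOC2(O3)C3CC4CC(C3)CC2C4)cc1` carries 1-amino-1-methylethyl in place of (piperidin-4-yl)oxy on a saturated chain carbon, two bonds along the chain from an oxygen on an aromatic ring; the step that the two limits leave unreadable from compound 1 to compound 2 cannot be sized, as both of its ends sit at the limit (the limit of < 7 mL.min-1.g-1 in this assay, at which 2 of the 2 values shown sit). In this assay compound 2 gives < 7 mL.min-1.g-1, again a limit of the assay and not a number. Compound 2 thus stands at the limit where every measured value of the set so far sits (the limit of < 7 mL.min-1.g-1 in this assay, at which 2 of the 2 values shown sit).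

Compound 3 `CC1(C)CC(O)(COc2ccc([C@H]3CC[C@]4(CC3)OOC3(O4)C4CC5CC(C4)CC3C5)cc2)CC(C)(C)N1` is the next compound to be measured. (4-hydroxy-2,2,6,6-tetramethylpiperidin-4-yl in place of 2-amino-2-methylpropyl on a saturated chain carbon bound to an oxygen on an aromatic ring). The one measured step, a step that the two limits leave unreadable from compound 1 to compound 2, is the only comparison that bears on this change, and it is not readable; no shown step exceeds the scatter. The step that the limit leaves unreadable from compound 2 to compound 3 is therefore expected to be none beyond the scatter, with a fair chance that compound 3 also returns only a limit. Compound 3 is estimated at 5 mL.min-1.g-1, within 2 mL.min-1.g-1 to 15 mL.min-1.g-1.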

Compound 3, intrinsic clearance in microsomes: 14 mL.min-1.g-1
The estimate for compound 3 lay 2.8-fold (0.45 log units) below the measured number; low and high end bracket the measured number.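

In this assay, for the compounds shown here, 4-hydroxy-2,2,6,6-tetramethylpiperidin-4-yl on a saturated chain carbon bound to an oxygen on an aromatic ring gives the first step at this place with a readable floor: an at least 2.0-fold higher number from compound 2 to compound 3 (0.30 log units; that floor lies within the scatter). Set against the side chain of compound 1, the same group gives a floor of the same kind: an at least 2.0-fold higher number from compound 1 to compound 3 (0.30 log units; that floor lies within the scatter). Neither floor alone shows a change beyond the scatter, but the set now holds one number alongside two assay limits, with compound 3 as the only compound off the limit: the limit of < 7 mL.min-1.g-1 in this assay, at which 2 of the 3 values shown sit.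

Going by these compounds, the true size of both steps stays open, since a floor gives no upper bound and the other end of each step is a limit rather than a number. Also open, on these data alone, is which part of the entering group goes with the number in this assay: a plain piperidin-4-yl, or a 2,2,6,6-tetramethylpiperidin-4-yl without the hydroxy, on the same chain carbon would separate the contribution of the hydroxy from that of the four methyl groups.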